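A few compounds are considered here, and "the series" means these few. Any claim that something is new, unique, unknown or untested is made for them only; others in the source may bear on it.

Measured in a functional assay on HepG2 cells (Homo sapiens) for inhibition, read by MTT assay, with a stated time of 24 h; a higher number here means a weaker inhibitor, a lower number a stronger inhibitor:
compound 1 `CC1(C)[C@H]2CC[C@]1(C)N(Cc1cn(-c3ccccc3C#N)nn1)C(=O)C2`: 180 nM
compound 2 `CC1(C)[C@H]2CC[C@]1(C)N(Cc1cn(-c3ccc(Br)cc3)nn1)C(=O)C2`: 110 nM

Only these two compounds have been measured so far in this assay, and they cannot be told apart: the step between them is a 1.6-fold lower number from compound 1 to compound 2 (0.21 log units; within the scatter). Compound 2, at 110 nM, therefore stands level with compound 1 within the scatter. Compound 3 `Cc1ccc(-n2cc(CN3C(=O)C[C@@H]4CC[C@@]3(C)C4(C)C)nn2)cc1` keeps the shared core and differs from compound 2 in one place: methyl in place of bromo on an aromatic carbon. Among the measured compounds shown here, no measured pair compares these two groups directly. The nearest evidence is the change from compound 1 to compound 2, a replacement of 2-cyanophenyl by 4-bromophenyl on an aromatic nitrogen, which gave only a 1.6-fold lower number from compound 1 to compound 2 (0.21 log units; within the scatter). That single step gives no reason to expect a large shift here, and no direction can be argued from it. The expected step is a 1.2-fold higher number from compound 2 to compound 3 (0.07 log units; within the scatter), so no change beyond the scatter is anticipated. For compound 3 the estimated value is 130 nM, with an expected range from 55 nM to 320 nM.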

Compound 3, half-maximal inhibitory concentration: 480 nM
The estimate for compound 3 lay 3.7-fold (0.57 log units) below the measured number; the whole stated range lies below it.
By their numbers in this assay, from the lowest: compounds 2 and 1 (each within the scatter of the next); then compound 3.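

In this assay, among the compounds shown here, the aromatic carbon para to a large group proves sensitive to its substituent: replacing bromo with methyl, a change that leaves the computed counts of heavy atoms, rings, hydrogen-bond donors and hydrogen-bond acceptors untouched, gives a 4.4-fold higher number from compound 2 to compound 3 (0.64 log units; beyond the scatter) and is the first step in this set to lie beyond the scatter. The 4-methylphenyl group also compares unfavourably with the 2-cyanophenyl group, with a 2.7-fold higher number from compound 1 to compound 3 (0.43 log units; beyond the scatter) on that exchange, so compound 3 is the weakest inhibitor of the three, whereas compound 1 and compound 2 could not be separated. Nothing available accounts for this loss when methyl takes the place of bromo.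

The compounds shown leave open whether the higher number is particular to methyl or whether other groups at this place, such as chloro, methoxy or an amine, would also part from compound 2. They also leave open whether a carboxylic acid or a longer chain at this place would give a number nearer that of compound 2 or that of compound 3.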